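From cycloheptyl to 4-ethylcyclohexyl: a half-life question

The source may hold more compounds than are shown below. What is called first, only, known or untested is meant among the compounds shown, and "the series" means these compounds.

In an ADME assay on the whole organism (strain Swiss Webster) for metabolic stability, with Mus musculus as the target, using cassette dosing, at a dose of 0.3 mg/kg by the oral route (a lower number here means that the compound disappears faster, a higher number that the compound lasts longer), compound 1 (`CCC(C)C(=O)N1CCC(NC(=O)Nc2ccc(C(F)(C(F)(F)F)C(F)(F)F)cc2)CC1`) gives 4.5 h and compound 2 (`CCC(C)C(=O)N1CCC(NC(=O)NC2CCCCCC2)CC1`) gives 8.4 h. These two values lie within the usual scatter of each other, so the numbers do not set compound 2 apart from compound 1. Compound 3 (`CCC(C)C(=O)N1CCC(NC(=O)N[C@H]2CC[C@H](CC)CC2)CC1`) carries 4-ethylcyclohexyl in place of cycloheptyl on an amide-type nitrogen. Among the compounds with values here, no two measured compounds differ in one place only, so nothing yet shows what such a swap does, and no change beyond the scatter is expected. The estimated change is small: a 1.2-fold lower number from compound 2 to compound 3 (0.08 log units; within the scatter). For compound 3 the expected half-life is 7 h, within an estimated range of 3 h to 15 h.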

Compound 3, half-life: 12 h
Compound 3: middle estimate off by 1.7-fold (0.23 log units), on the low side; low and high end bracket the measured number.
By their numbers in this assay, from the lowest: compounds 1, 2 and 3 (each within the scatter of the next, the first and the last beyond it).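

In this assay the first single-place comparison gives a 1.4-fold higher number from compound 2 to compound 3 (0.15 log units; within the scatter) for 4-ethylcyclohexyl in place of cycloheptyl on an amide-type nitrogen, and this lies within the scatter. At this position, then, a six-membered ring with an ethyl group and two defined stereocentres cannot be told apart from the seven-membered ring by half-life. Nothing measured here explains this result.

Still open, on these data alone, is how the half-life responds to a group of another kind on this nitrogen, such as an amine or a carboxylic acid. Also open, as far as these compounds go, is the effect of a longer chain in place of the ethyl group.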